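Exchanging an aromatic alkynyl substituent for a saturated ring

This account rests on a few compounds, and the source may have more. Where it says the series, first, only, none or still open, it means among the compounds named here.

Three analogues sharing a common core have been characterised so far. Compound 1 `CNC(=O)[C@@]12C[C@@H]1[C@@H](n1cnc3c(NC)nc(C#Cc4cc(C)c(C)o4)nc31)[C@H](O)[C@@H]2O` gives 1.45 nM in an assay on CHO cells for displacement of a labelled ligand from adenosine receptor A3 (Homo sapiens), read by scintillation counting, with a stated time of 60 min; a higher number here means a weaker inhibitor, a lower number a stronger inhibitor. Compound 2 `CNC(=O)[C@@]12C[C@@H]1[C@@H](n1cnc3c(NC)nc(C#Cc4ccsc4)nc31)[C@H](O)[C@@H]2O` gives 0.52 nM in this assay, and compound 3 `CNC(=O)[C@@]12C[C@@H]1[C@@H](n1cnc3c(NC)nc(C#Cc4nccs4)nc31)[C@H](O)[C@@H]2O` gives 2.1 nM. Compound 3 thus holds the highest number of the three, though its gap to compound 1 stays within the scatter, while the step of a 4.0-fold higher number from compound 2 to compound 3 (0.61 log units; beyond the scatter) lies beyond it. The other steps at the same position are a 2.8-fold lower number from compound 1 to compound 2 (0.45 log units; beyond the scatter) and a 1.4-fold higher number from compound 1 to compound 3 (0.16 log units; within the scatter).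

The step now followed leads to compound 4 `CNC(=O)[C@@]12C[C@@H]1[C@@H](n1cnc3c(NC)nc(C#CC4CCCCC4)nc31)[C@H](O)[C@@H]2O`, which differs from compound 3 by cyclohexyl in place of 1,3-thiazol-2-yl on a triple-bonded carbon. For the measured compounds named here, all the measured steps at this position replace one aromatic group by another aromatic group, and the largest of them stays modest; none of them exchanges an aromatic group for a saturated ring, so they guide only loosely. A modest rise in number is expected for compound 4, with a step of a 2.4-fold higher number from compound 3 to compound 4 (0.38 log units; beyond the scatter). The estimated value of compound 4 in this assay is 5 nM, with a range from 1 nM to 25 nM.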

Compound 4, inhibition constant: 1.68 nM
Estimate against measurement, compound 4: 3.0-fold (0.47 log units) above; the measured number falls inside the stated range.
By their numbers in this assay, from the lowest: compound 2; then compounds 1, 4 and 3 (each within the scatter of the next).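

In this assay, exchanging an aromatic group for a saturated ring on a triple-bonded carbon does not by itself move the number: a 1.3-fold lower number from compound 3 to compound 4 (0.10 log units; within the scatter) and a 1.2-fold higher number from compound 1 to compound 4 (0.06 log units; within the scatter) show that cyclohexyl reads level with both 1,3-thiazol-2-yl and 4,5-dimethylfuran-2-yl. An aromatic ring at this place is therefore not needed to reach the range of those two compounds, although thiophen-3-yl remains apart, with a 3.2-fold higher number from compound 2 to compound 4 (0.51 log units; beyond the scatter). Nothing measured here explains why the saturated and aromatic groups read alike or why thiophen-3-yl differs.

From the compounds shown here alone, what remains open is how a saturated ring of another size, such as cyclopropyl, or an open-chain group, such as a longer alkyl chain, would read at this place. Going by these compounds, it is equally open whether a cyclohexyl carrying an amine or a carboxylic acid would keep this number.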